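A Larger Side Chain on a Stable Bicyclic Core

The source may hold more compounds than are shown below. What is called first, only, known or untested is meant among the compounds shown, and "the series" means these compounds.

Of the compounds shown here, three sharing one core have been measured in an ADME assay, in phosphate buffer, at 28 degrees C, at pH 7.0; a higher number here means that the compound lasts longer, a lower number that the compound disappears faster. Compound 1 `CC(C)(C)C1=C(C(=O)O)N2C(=O)[C@H](CO)[C@H]2O1` gives 5 h. Compound 2 `C[C@@H](O)[C@H]1C(=O)N2C(C(=O)O)=C(C(C)(C)C)O[C@H]12` gives 8.1 h, and compound 3 `Cn1cc([C@@H](O)[C@H]2C(=O)N3C(C(=O)O)=C(C(C)(C)C)O[C@H]23)nn1` gives 6.8 h. The three numbers sit close together: a 1.6-fold higher number from compound 1 to compound 2 (0.21 log units; within the scatter), a 1.4-fold higher number from compound 1 to compound 3 (0.13 log units; within the scatter), and a 1.2-fold lower number from compound 2 to compound 3 (0.08 log units; within the scatter), so none of them can be told apart from the others.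

Compound 4 `CC(C)(C)C1=C(C(=O)O)N2C(=O)[C@H]([C@H](O)CCc3ccc(O)cc3)[C@H]2O1` is not yet measured. It differs from compound 2 by 4-hydroxybenzyl in place of hydrogen on a saturated chain carbon, two bonds along the chain from an oxygen on a saturated carbon and a saturated ring carbon. The earlier steps shown here all changed the same stretch of chain, swapping hydrogen for methyl or for 1-methyl-1H-1,2,3-triazol-4-yl, and each stayed within the scatter. Among the compounds with values here, a hydroxybenzyl group has not been tried, yet nothing measured so far suggests the chain governs how long the compounds last. The expected step in this assay is therefore a 1.0-fold lower number from compound 2 to compound 4 (0.01 log units; within the scatter), a change that would not exceed the scatter. The estimate for compound 4 is 8 h, with a range from 4 h to 16 h.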

Compound 4, half-life: 24.6 h
For compound 4 the middle estimate is 3.1-fold (0.49 log units) below the measured one; measured number above the stated range.
By their numbers in this assay, from the lowest: compounds 1, 3 and 2 (each within the scatter of the next); then compound 4.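

In this assay, putting 4-hydroxybenzyl on this saturated chain carbon gives a 3.0-fold higher number from compound 2 to compound 4 (0.48 log units; beyond the scatter) and is the only step shown here that lies beyond the scatter. The earlier changes to this stretch of chain, methyl and 1-methyl-1H-1,2,3-triazol-4-yl, left compounds 1, 2 and 3 indistinguishable, so they gave no sign that this position could affect how long a compound lasts; compound 4 shows that it can. Nothing available here explains the rise in half-life.

Compound 4 alone carries this group, so one step cannot show whether the six-membered aromatic ring, its hydroxyl or the added length of the chain matters. Plain benzyl, with no hydroxyl, and a ring carrying an amine or a carboxylic acid in place of the hydroxyl remain open, as does a longer chain.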